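A longer chain on the carbonyl: expecting compound 4

A few compounds are considered here, and "the series" means these few. Any claim that something is new, unique, unknown or untested is made for them only; others in the source may bear on it.

- compound 1 `C=C[C@@](C)(/C=C/c1ccc(OC(C)=O)cc1)CCC=C(C)C` gives 71%
- compound 2 `C=C[C@@](C)(/C=C/c1ccc(OC(=O)CCCC)cc1)CCC=C(C)C` gives 21%
- compound 3 `C=C[C@@](C)(/C=C/c1ccc(OC(=O)CCCCC)cc1)CCC=C(C)C` gives 19%

In a functional assay on IMR-32 cells (Homo sapiens) for inhibition, with a stated time of 48 h, tested at 50 uM (a lower number here means less inhibition of growth, a higher number more inhibition of growth at the concentration tested), compound 3 gives 19% and shares the low end of the range with compound 2, well apart from compound 1. Compound 4 `C=C[C@@](C)(/C=C/c1ccc(OC(=O)CCCCCCCCC)cc1)CCC=C(C)C` differs from compound 3 by butyl in place of hydrogen on a saturated chain carbon, five bonds along the chain from a carbonyl carbon. The large drops, a number 50 percentage points lower from compound 1 to compound 2 (beyond the scatter) and a number 52 percentage points lower from compound 1 to compound 3 (beyond the scatter), are less like this change than the step that also lengthens an already long chain, a number 2 percentage points lower from compound 2 to compound 3 (within the scatter), which shows no real change. The expected step is a number 2 percentage points lower from compound 3 to compound 4 (within the scatter), so none beyond the scatter is expected. Compound 4 is estimated at 17%, within a range from 5% to 35%.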

Compound 4, percent growth inhibition at one concentration: 52%
Compound 4: middle estimate off by 35 percentage points, on the low side; the measured number lies above the stated range.
By their numbers in this assay, from the lowest: compounds 3 and 2 (each within the scatter of the next); then compound 4; then compound 1.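

In this assay the chain on the carbonyl still matters at this length: butyl in place of hydrogen gives a number 33 percentage points higher from compound 3 to compound 4 (beyond the scatter) and the comparison with the shorter chain gives a number 31 percentage points higher from compound 2 to compound 4 (beyond the scatter) so the flat stretch seen earlier does not continue. The return is only partial, with a number 19 percentage points lower from compound 1 to compound 4 (beyond the scatter) so across these four compounds the number falls and then rises as the chain grows. Nothing available explains this rise.

Chains of lengths between those of compound 3 and compound 4 could show where the rise begins. From the compounds shown here alone, a still longer chain, or one ending in an amine or a carboxylic acid, remains open.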